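Replacing 3-fluorophenyl with thiophen-2-yl on the shared core

A few compounds are considered here, and "the series" means these few. Any claim that something is new, unique, unknown or untested is made for them only; others in the source may bear on it.

Measured so far (a functional assay on KB cells (Homo sapiens) for inhibition, with a stated time of 72 h; on this read-out higher numbers stand for weaker inhibition and lower numbers for stronger inhibition):
- compound 1 `COc1ccc(S(=O)(=O)N2CCc3cccc(-c4ccc(N)cc4)c32)cc1` gives 249 nM
- compound 2 `COc1ccc(-c2cccc3c2N(S(=O)(=O)c2ccc(OC)cc2)CC3)cc1` gives 337 nM
- compound 3 `COc1ccc(S(=O)(=O)N2CCc3cccc(-c4cccc(F)c4)c32)cc1` gives 98.5 nM

Compound 3 has the lowest number of the three (98.5 nM), which makes it the strongest inhibitor measured here. Compound 4 `COc1ccc(S(=O)(=O)N2CCc3cccc(-c4cccs4)c32)cc1` differs from it in one place, with thiophen-2-yl in place of 3-fluorophenyl on an aromatic carbon.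

For the measured compounds named here, no compound with a five-membered ring at this place has been measured, so the closest guide is what other ring swaps there have done. Two steps reach compound 3, and both are modest (a 2.5-fold lower number from compound 1 to compound 3 (0.40 log units; beyond the scatter); a 3.4-fold lower number from compound 2 to compound 3 (0.53 log units; beyond the scatter)). The third step stays within the scatter (a 1.4-fold higher number from compound 1 to compound 2 (0.13 log units; within the scatter)).

Ring swaps here have therefore moved the number only a little, and compound 3 already sits at the low end. A small rise seems more likely than a further fall, though the data cannot settle the direction. In this assay the expected step is a 1.5-fold higher number from compound 3 to compound 4 (0.18 log units; within the scatter) and a large change is not expected. Compound 4 is estimated at 150 nM with an expected range (50 nM to 400 nM).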

Compound 4, half-maximal inhibitory concentration: 215 nM
For compound 4 the middle estimate is 1.4-fold (0.16 log units) below the measured one, and the stated range covers the measured number.
By their numbers in this assay, from the lowest: compound 3; then compounds 4, 1 and 2 (each within the scatter of the next).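

In this assay, thiophen-2-yl is the only five-membered aromatic ring among these compounds, and putting it in place of 3-fluorophenyl gives a 2.2-fold higher number from compound 3 to compound 4 (0.34 log units; beyond the scatter) on the shared core, so this position accepts the smaller ring but does not match the result with 3-fluorophenyl. The new compound cannot be separated from those carrying a para-free comparison of the earlier groups: thiophen-2-yl in place of 4-methoxyphenyl gives (a 1.6-fold lower number from compound 2 to compound 4 (0.20 log units; within the scatter)) and in place of 4-aminophenyl gives (a 1.2-fold lower number from compound 1 to compound 4 (0.06 log units; within the scatter)), so among the four groups only 3-fluorophenyl stands apart, with thiophen-2-yl, 4-methoxyphenyl and 4-aminophenyl forming one level. No outside data bear on why 3-fluorophenyl differs from thiophen-2-yl.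

The step changes ring size, swaps fluorine for sulfur and alters the ring's atoms all at once, so the compounds leave open which of these differences matters. Plain phenyl, which carries neither fluorine nor sulfur, and furan-2-yl, which has oxygen in the ring where thiophen-2-yl has sulfur, would help pull these differences apart.

Correction to the wording above: the phrase "para-free comparison" should be read simply as "the earlier groups".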